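The source may hold more compounds than are shown below. What is called first, only, known or untested is meant among the compounds shown, and "the series" means these compounds.

Series values in a functional assay on SMMC-7721 cells (Homo sapiens) for antiproliferative activity, read by MTT assay, with a stated time of 48 h; a lower number here means a stronger inhibitor, a higher number a weaker inhibitor:
- compound 1 `CC(=O)OC/C1=C/C[C@](C)(CCC=C(C)C)/C=C/[C@@H](OC(=O)C=C(C)C)[C@](C)(O)/C=C/C1=O`: 2950 nM
- compound 2 `COCOC/C1=C/C[C@](C)(CCC=C(C)C)/C=C/[C@@H](OC(=O)C=C(C)C)[C@](C)(O)/C=C/C1=O`: 3250 nM
- compound 3 `CC(C)=CCC[C@]1(C)/C=C/[C@@H](OC(=O)C=C(C)C)[C@](C)(O)/C=C/C(=O)/C(Cn2cc(CO)nn2)=C\C1`: 3560 nM

Compound 3 stands level with the other two, since a 1.2-fold higher number from compound 1 to compound 3 (0.08 log units; within the scatter) and a 1.1-fold higher number from compound 2 to compound 3 (0.04 log units; within the scatter) both lie within the scatter. The next compound is compound 4 `CC(C)=CCC[C@]1(C)/C=C/[C@@H](OC(=O)C=C(C)C)[C@](C)(O)/C=C/C(=O)/C(C(=O)N(C(C)C)C(C)C)=C\C1`, and the change to it is diisopropylcarbamoyl in place of (4-(hydroxymethyl)-1H-1,2,3-triazol-1-yl)methyl on a double-bonded ring carbon. The diisopropylcarbamoyl group therefore sits on the double-bonded ring carbon itself.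

The three measured steps bear on this only in part. Each exchanges a group on the saturated chain carbon bound to that ring carbon, and a 1.1-fold higher number from compound 1 to compound 2 (0.04 log units; within the scatter) is as flat as the two steps to compound 3. Among the compounds with values here, no measured compound lacks that chain carbon or carries a diisopropylcarbamoyl group, so the series offers no direct precedent. Going by the flat steps from compound 1, no shift beyond the scatter is expected in this assay, though with wide uncertainty. The expected step is a 1.1-fold higher number from compound 3 to compound 4 (0.05 log units; within the scatter). For compound 4 the estimated value is 4000 nM, with an expected range of 1500 nM to 12000 nM.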

Compound 4, half-maximal inhibitory concentration: 17200 nM
Compound 4: middle estimate off by 4.3-fold (0.63 log units), on the low side; measured number outside the range, above it.
By their numbers in this assay, from the lowest: compounds 1, 2 and 3 (each within the scatter of the next); then compound 4.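

In this assay this double-bonded ring carbon does not tolerate every change: diisopropylcarbamoyl on the ring carbon itself gives a 4.8-fold higher number from compound 3 to compound 4 (0.68 log units; beyond the scatter) and a 5.3-fold higher number from compound 2 to compound 4 (0.72 log units; beyond the scatter) as well as a 5.8-fold higher number from compound 1 to compound 4 (0.77 log units; beyond the scatter) with all three steps modest in size. Within the data shown here, the earlier exchanges on the saturated chain carbon stayed within the scatter, so this is the first change to move the number beyond it, and it also removes that chain carbon. No measurement available here bears on the reason for the rise.

The change replaces both the chain carbon and the group it carried, so the compounds shown leave open which of the two matters. A diisopropylaminomethyl group on the ring carbon, or a carboxylic acid or dimethylcarbamoyl group there, would help separate them.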